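Swapping an acyl chain for a methoxyphenyl group

The source may hold more compounds than are shown below. What is called first, only, known or untested is meant among the compounds shown, and "the series" means these compounds.

Of the compounds shown here, two that share one core have been tested in a functional assay on WI-38 VA13 cells (Homo sapiens) for cytotoxicity; on this read-out higher numbers stand for an effect only at larger amounts of compound and lower numbers for an effect already at smaller amounts. Compound 1 `O=C(Nc1ccc2nc(NC(=O)C3CCCCC3)sc2c1)c1ccccc1Oc1ccccc1` gives 0.1 ug/mL in this assay. Compound 2 `CCCCCCCC(=O)Nc1nc2ccc(NC(=O)c3c(Cl)cccc3Cl)cc2s1` gives 0.18 ug/mL in this assay, and these two numbers lie within the usual scatter of each other, so they count as equal. Compound 3 `COc1ccc(Nc2nc3ccc(NC(=O)c4c(Cl)cccc4Cl)cc3s2)cc1` has not yet been measured. It differs from compound 2 in one place: 4-methoxyphenyl in place of heptylcarbonyl on a nitrogen on an aromatic ring. For the measured compounds named here, no measured pair shows this exchange, so any expectation rests on compound 2 alone. A modest step toward higher numbers, possibly not beyond the scatter, is expected: a 1.7-fold higher number from compound 2 to compound 3 (0.22 log units; within the scatter). Compound 3 is estimated at 0.3 ug/mL, with a range from 0.08 ug/mL to 1.2 ug/mL.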

Compound 3, half-maximal effective concentration: 0.87 ug/mL
Estimate against measurement, compound 3: 2.9-fold (0.46 log units) below; low and high end bracket the measured number.
By their numbers in this assay, from the lowest: compounds 1 and 2 (each within the scatter of the next); then compound 3.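

On a nitrogen on an aromatic ring, the exchange of heptylcarbonyl for 4-methoxyphenyl is not neutral: in this assay it gives a 4.8-fold higher number from compound 2 to compound 3 (0.68 log units; beyond the scatter), beyond the scatter. So this position responds to what it carries, and with the 4-methoxyphenyl group a larger amount of compound is needed for the effect. No measurement at hand explains this step.

The compounds shown leave open whether the loss of the carbonyl, the arrival of the ring or the methoxy group drives the change. A plain heptyl chain or an unsubstituted phenyl on the same nitrogen would help separate these.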